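Unspecified stereochemistry at a ring carbon of compound 3

The source may report more compounds than this note shows. Statements on the series, on what has been measured and on what is new or still open speak of the compounds shown alone.

Compound 1 `O=C1C2CCCN2C(=O)N1CN1CCN(c2cccc3[nH]cnc23)CC1` in an assay on membranes from Cerebral cortex for binding affinity to Adrenergic receptor alpha-1 (Rattus norvegicus) (a higher number here means a weaker inhibitor, a lower number a stronger inhibitor), gives > 1000 nM, a limit of the assay rather than a number.
Compound 2 `O=C1C2CCCN2C(=O)N1CCCCN1CCN(c2cccc3[nH]cnc23)CC1` in this assay gives 19.4 nM.
Compound 3 `O=C1[C@@H]2CCCN2C(=O)CN1CN1CCN(c2cccc3c2CC=COO3)CC1` in this assay gives > 1000 nM, again only a limit.

Compound 3 thus stands at the weak end of what has been measured, at a limit shared by two of the three values (the limit of > 1000 nM in this assay, at which 2 of the 3 values shown sit). Compound 4 `O=C1C2CCCN2C(=O)CN1CN1CCN(c2cccc3c2CC=COO3)CC1` differs from it only in how one centre is drawn: the two compounds have the same atoms and bonds; at least one stereo element is drawn with a configuration in one of them and without one in the other: 1 of 1 stereo elements differ; a stereocentre at a saturated ring carbon is drawn S in compound 3 and without a configuration in compound 4. Since compound 4 contains the same material as compound 3 among whatever else may be present, no step beyond the scatter is expected, and the limit of compound 3 > 1000 nM most likely recurs. Compound 4 is estimated at 2000 nM, between 400 nM and 10000 nM, a step that the limit leaves unreadable from compound 3 to compound 4.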

Compound 4, inhibition constant: > 1000 nM
Compound 4 ended at the assay's limit; the forecaster's own chance of this, stated with the estimate: 70%; the middle value does not contradict the limit.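

Within the data shown here, compound 3 and compound 4 both end at a limit in this assay, so no step between them can be read. The compounds shown leave open whether the configuration drawn at the saturated ring carbon makes any difference.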